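The compounds below may be only part of what the source reports. "The series", "measured", "known", "first", "only" and "open" are said of these compounds alone.

In an assay on MDA-MB-231 cells for binding affinity to C-X-C chemokine receptor type 4 (Homo sapiens), read by immunofluorescence and microscopy, with stated times of 10 min and 30 min (a lower number here means that less compound is needed, a higher number that more compound is needed for the effect), compound 3 `Cc1ccc(S(=O)(=O)NCc2ccc(CNC(=O)c3ccc(Cl)cc3)cc2)cc1` gives 10 nM, the higher of the two numbers shown. Compound 2 `Cc1ccc(S(=O)(=O)NCc2ccc(CNC(=O)c3ccc(F)cc3)cc2)cc1` gives 1 nM, and the step of a 10-fold higher number from compound 2 to compound 3 (1.00 log units; beyond the scatter) is beyond the scatter. Compound 1 `Cc1ccc(S(=O)(=O)NCc2ccc(CNC(=O)c3ccccc3)cc2)cc1` gives only a limit, > 1000 nM, as the limit of > 1000 nM in this assay, at which 1 of the 3 values shown sits, records. Compound 4 `Cc1ccc(S(=O)(=O)NCc2ccc(CNC(=O)c3ccncc3)cc2)cc1` differs from compound 3 by pyridin-4-yl in place of 4-chlorophenyl on a carbonyl carbon. The measured steps all concern what sits on an aromatic carbon of the ring that leaves: an at least 1000-fold lower number from compound 1 to compound 2 (3.00 log units; beyond the scatter) and an at least 100-fold lower number from compound 1 to compound 3 (2.00 log units; beyond the scatter) show that a halogen there, in place of hydrogen, brings the number down by a large amount. Compound 4 carries no halogen at all, so a large step upward is expected, a 30-fold higher number from compound 3 to compound 4 (1.48 log units; beyond the scatter). Compound 4 is therefore estimated at 300 nM, between 30 nM and 3000 nM, with a real chance that only a limit is reported.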

Compound 4, effective concentration (reported as EC, without a stated level of effect): 10 nM
For compound 4 the middle estimate is 30-fold (1.48 log units) above the measured one; the measured number lies below the stated range.
By their numbers in this assay, from the lowest: compound 2; then compounds 3 and 4 (each within the scatter of the next). At a limit, above all of these: compound 1.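

A halogen is not needed on this ring to reach a low number: pyridin-4-yl, which has none, gives no change at the digits printed from compound 3 to compound 4 (within the scatter) and an at least 100-fold lower number from compound 1 to compound 4 (2.00 log units; beyond the scatter). The second step has only a minimum size, as compound 1 is a limit: the limit of > 1000 nM in this assay, at which 1 of the 4 values shown sits. The 4-fluorophenyl group still gives the lowest number, with a 10-fold higher number from compound 2 to compound 4 (1.00 log units; beyond the scatter).

As far as these compounds go, what remains open is whether the ring nitrogen matters in itself, and how pyridin-3-yl would compare. Also open, from the compounds shown here alone, is how a ring carrying an amine or a carboxylic acid would behave on this carbonyl carbon.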